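Cyclopropyl to 2-methoxyphenyl on the chain of compound 2

The source may hold more compounds than are shown below. What is called first, only, known or untested is meant among the compounds shown, and "the series" means these compounds.

Compound 1 `O=C(O)c1ccccc1-c1ccc(CCc2ncc(CCC3CCCCC3)[nH]2)cc1`: in an in vitro functional assay on cells for agonist activity at Bombesin receptor subtype-3 (Homo sapiens), read by luminescence and calcium flux (on this read-out lower numbers stand for an effect already at smaller amounts and higher numbers for an effect only at larger amounts of compound), compound 1 gives 642 nM
Compound 2 `O=C(O)c1ccccc1-c1ccc(CCc2ncc(CC3CC3)[nH]2)cc1`: in this assay compound 2 gives 1000 nM

Going by the values given here, compound 2 has the highest of the two numbers, and its only neighbour is compound 1, with a 1.6-fold higher number from compound 1 to compound 2 (0.19 log units; within the scatter). Compound 3 `COc1ccccc1Cc1cnc(CCc2ccc(-c3ccccc3C(=O)O)cc2)[nH]1` carries the change (2-methoxyphenyl in place of cyclopropyl on a saturated chain carbon bound to an aromatic carbon). Among the compounds with values here, the single measured step, from cyclohexylmethyl to cyclopropyl, stayed within the scatter, and no measured step bears on an aromatic group at this place. Compound 3 is therefore expected to land near compound 2 or somewhat lower, estimated as a 2.0-fold lower number from compound 2 to compound 3 (0.30 log units; within the scatter). The estimate for compound 3 is 500 nM, within 150 nM to 1600 nM.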

Compound 3, half-maximal effective concentration: 1720 nM
Compound 3: the middle estimate sits 3.4-fold (0.54 log units) below what was measured; the whole stated range lies below it.
By their numbers in this assay, from the lowest: compounds 1, 2 and 3 (each within the scatter of the next, the first and the last beyond it).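

Placing an aromatic group on this saturated chain carbon, 2-methoxyphenyl in place of cyclopropyl, gives in this assay a 1.7-fold higher number from compound 2 to compound 3 (0.24 log units; within the scatter) and so does not separate the two compounds. Set against cyclohexylmethyl, the same aromatic group gives a 2.7-fold higher number from compound 1 to compound 3 (0.43 log units; beyond the scatter) as the first step at this place to clear the scatter, though only modestly. Nothing available explains this result.

The compounds shown leave open what a plain phenyl, an amine or a longer chain would give at this place. They also leave open whether the methoxy group itself contributes to the result.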